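This account rests on a few compounds, and the source may have more. Where it says the series, first, only, none or still open, it means among the compounds named here.

Measured compounds:
- compound 1, `COc1cc2cc(Oc3ccc(NC(=O)Nc4ccccc4)cc3)c(C)nc2cc1OC`, 63.4% in a functional assay on EKVX cells (Homo sapiens) for inhibition, read by sulforhodamine B assay, with a stated time of 48 h, tested at 10 uM; a higher number here means a weaker effect of the compound at the concentration tested, a lower number a stronger effect
- compound 2, `COc1cc2cc(Oc3ccc(NC(=O)Nc4ccc(C(F)(F)F)cc4)cc3)c(C)nc2cc1OC`, 75.7%
- compound 3, `COc1cc2cc(Oc3ccc(NC(=O)Nc4cccc(C(F)(F)F)c4)cc3)c(C)nc2cc1OC`, 15.4%

Compound 3 gives the lowest of the three numbers, meaning the strongest effect here; compound 1 stands nearest, as the step of a number 48 percentage points lower from compound 1 to compound 3 (beyond the scatter) shows, and compound 2 furthest, as the step of a number 60.3 percentage points lower from compound 2 to compound 3 (beyond the scatter) shows. The step of a number 12.3 percentage points higher from compound 1 to compound 2 (beyond the scatter) is smaller. Compound 4, `COc1cc2cc(Oc3ccc(NC(=O)Nc4ccc(Cl)c(C(F)(F)F)c4)cc3)c(C)nc2cc1OC`, is not yet measured. It differs from compound 3 by chloro in place of hydrogen on an aromatic carbon. Among the measured compounds shown here, none of the measured steps involves a chloro group; they concern only where a trifluoromethyl group sits, so they say little about what this change will do. Without a directly bearing step, the expectation is that compound 4 stays close to compound 3, with a step of a number 8.6 percentage points higher from compound 3 to compound 4 (within the scatter) expected, which lies within the scatter but with a wide range. The estimate for compound 4 is 24%, expected to fall between 6% and 58%.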

Compound 4, a percentage reported as activity, at one concentration (the size of the read-out at that concentration, not a potency): 8.83%
Compound 4: the middle estimate sits 15.2 percentage points above what was measured; the measured number falls inside the stated range.
By their numbers in this assay, from the lowest: compounds 4 and 3 (each within the scatter of the next); then compound 1; then compound 2.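

Chloro on the aromatic carbon ortho to a trifluoromethyl group leaves the strong effect of compound 3 in place in this assay, with the step of a number 6.6 percentage points lower from compound 3 to compound 4 (within the scatter). The 4-chloro-3-(trifluoromethyl)phenyl group also stands far from the 4-(trifluoromethyl)phenyl group and from plain phenyl, with steps of a number 66.9 percentage points lower from compound 2 to compound 4 (beyond the scatter) and a number 54.6 percentage points lower from compound 1 to compound 4 (beyond the scatter), so a substituent in the 4-position of this ring does not by itself bring the weak result of compound 2. Nothing available explains why these two groups in the 4-position differ so much in their company.

As far as these compounds go, whether a methoxy group, an amine or a carboxylic acid on this same carbon would also keep the effect remains open. So does what the 4-chlorophenyl group would do without the trifluoromethyl group.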